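The compounds below may be only part of what the source reports. "The series", "measured", "known", "first", "only" and "open" are said of these compounds alone.

Measured in a functional assay on MCF7 cells (Homo sapiens) for antiproliferative activity; on this read-out higher numbers stand for weaker inhibition and lower numbers for stronger inhibition:
- compound 1 `Nc1ccc(-c2nc3ccccc3s2)cc1Cl`: < 1 nM (a limit)
- compound 2 `CC(=O)N(C(C)=O)c1ccc(-c2nc3ccccc3s2)cc1`: > 100 nM (a limit)

Compound 2 is known only through its limit of > 100 nM, not through a number. For the measured compounds named here, the only other value is also a limit, so the gap between the two compounds has no exact size.

Compound 3 `CC(=O)N(C(C)=O)c1ccc(-c2nc3ccccc3s2)cc1Cl` is compound 2 with chloro in place of hydrogen on an aromatic carbon. Going by the values given here, no measured pair isolates this change. The same chloro is present in compound 1, whose limit is < 1 nM, but compound 1 lacks the diacetylamino group. In this assay the change is expected to give stronger inhibition, beyond the scatter but of uncertain size, with an estimated at least 2.0-fold lower number from compound 2 to compound 3 (0.30 log units; that floor lies within the scatter). The estimate for compound 3 is 50 nM, with an expected range of 2 nM to 1000 nM.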

Compound 3, half-maximal inhibitory concentration: > 10000 nM
Compound 3 ended at the assay's limit; the forecaster's own chance of this, stated with the estimate: 40%; middle value at least 200-fold (2.30 log units) from the limit.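

In this assay compound 3 is known only through a limit: the limit of > 10000 nM in this assay, at which 1 of the 3 values shown sits. The step between compound 2 and compound 3 cannot be read, as both values are limits, and so the chloro ortho to a diacetylamino group has no readable size here in either direction. With the chloro held constant, diacetylamino in place of amino gives an at least 10000-fold higher number from compound 1 to compound 3 (4.00 log units; beyond the scatter), so the chloro shared with compound 1 does not keep that strength once the diacetylamino group is present.

Still open, on these data alone, is what the chloro does beside a free amine, for which the partner of compound 1 carrying hydrogen in place of chloro would be needed. Also open, as far as these compounds go, is whether a single acetyl group on the nitrogen, or a methylamino group, would read closer to compound 1 or to compound 3.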